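This account rests on a few compounds, and the source may have more. Where it says the series, first, only, none or still open, it means among the compounds named here.

Working notes on the series. Three compounds have a number in a toxicity assay on the whole organism (strain Icem-CET (SPF Caw)) for cytotoxicity, with Mus musculus as the target; on this read-out higher numbers stand for an effect only at larger amounts of compound and lower numbers for an effect already at smaller amounts. Compound 1 `C/C(C(=O)NC1CC1)=C(/C)c1ccc(Br)cc1` gives 600 mg/kg. Compound 2 `C#CCNC(=O)/C(C)=C(\C)c1ccc(OC)cc1` gives 400 mg/kg, the second highest of the three numbers; its nearest neighbour is compound 3 `C=CCNC(=O)/C(C)=C(\C)c1ccc(OC)cc1`, which gives 300 mg/kg, and its furthest is compound 1, whose number sits close by as well, so all three lie together within the scatter of the read-out.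

The step to compound 4 `C#CCNC(=O)/C(C)=C(\C)c1ccccc1` is hydrogen in place of methoxy on an aromatic carbon. Among the compounds with values here, only one measured step exists, a 1.3-fold lower number from compound 2 to compound 3 (0.12 log units; within the scatter), and it changes the group on the chain carbon bound to the amide nitrogen, not the aromatic ring; it shows that a small change at a remote position leaves this assay unmoved. Within the data shown here, no measured step changes the substituent on the aromatic ring alone: compound 1 differs from compound 2 in two places at once, and its number in this assay stays close to that of compound 2. On this basis the change from methoxy to hydrogen is expected to give no step beyond the scatter, no change at the digits printed from compound 2 to compound 4 (within the scatter). Compound 4 is therefore estimated at 400 mg/kg, with a range from 200 mg/kg to 800 mg/kg.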

Compound 4, dose for half-maximal effect: 400 mg/kg
The estimate for compound 4 equals the measured number at the digits printed; the measured number falls inside the stated range.
By their numbers in this assay, from the lowest: compounds 3, 2, 4 and 1 (each within the scatter of the next).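

In this assay, hydrogen in place of methoxy on an aromatic carbon, para to a large group, gives no change at the digits printed from compound 2 to compound 4 (within the scatter). Within the data shown here, this is the only measured step that changes the aromatic ring substituent and nothing else, so the series now has a direct reading at this position rather than one inferred from a change elsewhere in the molecule. Between these two compounds, the loss of the methoxy group, with its 2 heavy atoms and 1 hydrogen-bond acceptor, leaves the number within the scatter, and no data shown offer an explanation for this result.

The compounds shown leave open whether a different group at this position, such as an amine, a carboxylic acid or a longer alkoxy chain, would also stay within the scatter. Bromine on the ring appears only in compound 1, which also differs in the group on the amide nitrogen, so the contribution of that halogen alone cannot be read from the present set.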